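Swapping a chlorophenyl for cyclopropyl on the ring amide

The source may report more compounds than this note shows. Statements on the series, on what has been measured and on what is new or still open speak of the compounds shown alone.

Of the compounds shown here, three with a shared core have been measured in a functional assay on HepG2 cells (Homo sapiens) for antiproliferative activity, read by MTT assay, with a stated time of 72 h; on this read-out lower numbers stand for stronger inhibition and higher numbers for weaker inhibition. Compound 1 `O=C1COc2ccc(-c3cnc(Cl)c(NS(=O)(=O)c4ccc(F)cc4)c3)cc2N1c1ccccc1` gives 35700 nM. Compound 2 `O=C1COc2ccc(-c3cnc(Cl)c(NS(=O)(=O)c4ccc(F)cc4)c3)cc2N1c1ccc(Cl)cc1` gives 33900 nM, and the step of a 1.1-fold lower number from compound 1 to compound 2 (0.02 log units; within the scatter) stays within the scatter. For the measured compounds named here, compound 3 `COc1ncc(-c2ccc3c(c2)N(c2ccc(Cl)cc2)C(=O)CO3)cc1NS(=O)(=O)c1ccc(F)cc1` gives 17900 nM, the lowest of the three numbers, though the step of a 1.9-fold lower number from compound 2 to compound 3 (0.28 log units; within the scatter) is also within the scatter, so no compound can be called more potent than another. Compound 4 `COc1ncc(-c2ccc3c(c2)N(C2CC2)C(=O)CO3)cc1NS(=O)(=O)c1ccc(F)cc1` differs from compound 3 by cyclopropyl in place of 4-chlorophenyl on an amide-type nitrogen in a ring. Going by the values given here, no measured step replaces one ring with another; the only step touching the same nitrogen substituent, from compound 1 to compound 2, was within the scatter. Compound 4 is therefore expected near compound 3, with the step of a 1.1-fold higher number from compound 3 to compound 4 (0.05 log units; within the scatter) estimated as small. Compound 4 is estimated at 20000 nM, between 6000 nM and 60000 nM.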

Compound 4, half-maximal inhibitory concentration: 14400 nM
Compound 4: the middle estimate sits 1.4-fold (0.14 log units) above what was measured, within the range that was stated.
By their numbers in this assay, from the lowest: compounds 4, 3, 2 and 1 (each within the scatter of the next, the first and the last beyond it).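

At the amide-type nitrogen in the ring, this assay shows a 1.2-fold lower number from compound 3 to compound 4 (0.09 log units; within the scatter) when cyclopropyl replaces 4-chlorophenyl. The earlier step at this nitrogen only added a chloro to the phenyl, whereas this one removes the six-membered aromatic ring altogether, going from 7 heavy atoms to 3, and the numbers still cannot be told apart. No evidence is available that bears on the reason for this result.

From the compounds shown here alone, it remains open whether a longer carbon chain, an amine or a carboxylic acid on this nitrogen would move the number beyond the scatter.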